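Adding a second trifluoromethyl to the urea of compound 1

The source may hold more compounds than are shown below. What is called first, only, known or untested is meant among the compounds shown, and "the series" means these compounds.

Among the compounds with values here, compound 1 `COc1cc(Cl)cc(-c2nn(-c3cccc(NC(=O)Nc4cccc(C(F)(F)F)c4)c3)cc2-c2ccncc2)c1` is one of two compounds measured in a functional assay on SF-539 cells (Homo sapiens) for inhibition, read by sulforhodamine B assay, with a stated time of 48 h, tested at 100 uM; on this read-out lower numbers stand for a stronger effect and higher numbers for a weaker effect at the one concentration tested. In this assay compound 1 gives -72%, the lowest of the two numbers. Its nearest neighbour is compound 2 `COc1cc(Cl)cc(-c2nn(-c3cccc(NC(=O)c4cccc(C(F)(F)F)c4)c3)cc2-c2ccncc2)c1`, which gives 53% in this assay. Within the data shown here, the single measured step, a number 125 percentage points higher from compound 1 to compound 2 (beyond the scatter), is large and well beyond the scatter, and it comes with a 3-(trifluoromethyl)phenyl in place of a (3-(trifluoromethyl)phenyl)amino on the carbonyl carbon.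

Compound 3 `COc1cc(Cl)cc(-c2nn(-c3cccc(NC(=O)Nc4cc(C(F)(F)F)cc(C(F)(F)F)c4)c3)cc2-c2ccncc2)c1` has not yet been measured in this assay. It keeps the urea of compound 1 and differs only by trifluoromethyl in place of hydrogen on an aromatic carbon. No measured step touches this kind of change, so the one step shown from compound 1 to compound 2 does not bear on it directly; it only shows how far this read-out can move when the urea itself is altered. With the urea kept, he expects a step of about a number 12 percentage points higher from compound 1 to compound 3 (beyond the scatter), that is, no change beyond the scatter. His estimate for compound 3 in this assay is therefore -60%, within a range from -100% to 10%.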

Compound 3, a percentage reported as activity, at one concentration (the size of the read-out at that concentration, not a potency): -73%
Compound 3: middle estimate off by 13 percentage points, on the high side; the measured number falls inside the stated range.
By their numbers in this assay, from the lowest: compounds 3 and 1 (each within the scatter of the next); then compound 2.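

In this assay, adding a trifluoromethyl on an aromatic carbon, meta to a trifluoromethyl group, gives a number 1 percentage points lower from compound 1 to compound 3 (within the scatter), so this place on the aromatic ring of the urea accepts a further group of 4 heavy atoms without a shift that the read-out can distinguish. The earlier step, a number 125 percentage points higher from compound 1 to compound 2 (beyond the scatter), showed only what happens when the urea itself is altered, whereas this one shows that with the urea kept, a change on the ring leaves the number within the scatter. Nothing available explains why the added group leaves the read-out where it stands.

Since both compounds were read at a single concentration, the result cannot say whether compound 1 and compound 3 would also match at lower concentrations, where one could show a stronger or weaker effect at that concentration than the other. It also leaves open whether an amine or a carboxylic acid at this same place would keep the number within the scatter of compound 1, and whether the second trifluoromethyl would behave in the same way on the amide of compound 2.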